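Removing the fluorine from compound 1

The source may report more compounds than this note shows. Statements on the series, on what has been measured and on what is new or still open speak of the compounds shown alone.

Measured so far:
compound 1 `COc1ccc(C2=C(c3cc(OC)c(OC)c(OC)c3)C(=O)C(OC(C)=O)C2)cc1F` gives 39.5 ug/mL
compound 2 `C=CCOc1cc(C2=C(c3cc(OC)c(OC)c(OC)c3)C(=O)C(O)C2)ccc1OC` reaches only a limit, > 100 ug/mL
compound 3 `COc1ccc(C2=C(c3cc(OC)c(OC)c(OC)c3)CC(O)C2=O)cc1N` reaches only a limit, > 100 ug/mL

Among the compounds with values here, in an ADME assay on MIA PaCa-2 cells (Homo sapiens) for cytotoxicity, read by MTT assay, with a stated time of 72 h (a higher number here means a weaker inhibitor, a lower number a stronger inhibitor), compound 1 is the one compound with a number rather than a limit. Compound 2 gives a limit of the assay, not a number, at > 100 ug/mL. Compound 3 likewise gives a limit, > 100 ug/mL. Two of the three results therefore sit at the limit of > 100 ug/mL in this assay, at which 2 of the 3 values shown sit, and compound 1 stands alone as the measured point of reference.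

Compound 4 `COc1ccc(C2=C(c3cc(OC)c(OC)c(OC)c3)C(=O)C(OC(C)=O)C2)cc1` differs from compound 1 in one place: hydrogen in place of fluoro on an aromatic carbon. Within the data shown here, no step between measured compounds is available, so there is nothing to gauge this change against. A single fluoro leaving in favour of hydrogen is a small change in atom count, and the expectation is that the step of a 1.1-fold higher number from compound 1 to compound 4 (0.06 log units; within the scatter) stays within the usual scatter of this assay, with no clear direction. Compound 4 is therefore estimated at 45 ug/mL, expected to fall between 20 ug/mL and 100 ug/mL.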

Compound 4, half-maximal inhibitory concentration: < 1 ug/mL
Compound 4: no number, only a limit; the forecaster's own chance of this, stated with the estimate: 25%; at least 45-fold (1.65 log units) between middle value and limit.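

In this assay, exchanging one fluoro for hydrogen, on an aromatic carbon ortho to a methoxy group, gives an at least 39-fold lower number from compound 1 to compound 4 (1.59 log units; beyond the scatter). The earlier compounds shown here offered no pair differing in one place, and this step shows that the change from 3-fluoro-4-methoxyphenyl to 4-methoxyphenyl alone can move the result far beyond the scatter, even though only one heavy atom leaves. Compound 4 reaches a limit of the assay rather than a number, so the full size of the step stays unknown: the limit of < 1 ug/mL in this assay, at which 1 of the 4 values shown sits.

Only hydrogen and fluoro are shown at this position, so it remains open whether a chloro or a methyl group there would track compound 1 or compound 4. Within the data shown here, also open is how much the acetate ester contributes, as no pair here isolates it from a hydroxyl group.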